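From Cyclohexyl to Benzyl on the Amide Nitrogen

The source may report more compounds than this note shows. Statements on the series, on what has been measured and on what is new or still open speak of the compounds shown alone.

Compound 1, `CC(C)C(NC(=O)NO)C(=O)NC1CCCCC1`, gives > 100000 nM in a functional assay on MCF7 cells (Homo sapiens) for inhibition; on this read-out higher numbers stand for weaker inhibition and lower numbers for stronger inhibition; this value is a limit of the assay, not a number.
Compound 2, `CCC(C)C(NC(=O)n1nnc2ccccc21)C(=O)NC(c1ccccc1)c1ccccc1`, gives > 100000 nM in this assay; this too is a limit of the assay.
Compound 3, `CCC(C)C(NC(=O)n1nnc2ccccc21)C(=O)NC1CCCCC1`, gives 63100 nM in this assay.

Among the three measured compounds, compound 3 stands apart in that it alone yields a number, the other two reaching only (the limit of > 100000 nM in this assay, at which 2 of the 3 values shown sit). Among the measured compounds shown here, it is weak even so, and no pair of measured compounds differs in a single place, so no measured step is available to lean on.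

Compound 4, `CCC(C)C(NC(=O)n1nnc2ccccc21)C(=O)NCc1ccccc1`, is the untested member. It differs from compound 3 by benzyl in place of cyclohexyl on an amide-type nitrogen. Without a measured step of this kind, the change is expected to stay close to the scatter, leaning if anything toward weaker inhibition: the step is estimated at a 1.3-fold higher number from compound 3 to compound 4 (0.10 log units; within the scatter). For compound 4 the expected value in this assay is 80000 nM, within a range from 20000 nM to 300000 nM, with a fair chance that only a limit is reported.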

Compound 4, half-maximal inhibitory concentration: 69200 nM
The estimate for compound 4 lay 1.2-fold (0.06 log units) above the measured number; the range from low to high includes it.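

Among the compounds shown here, on the amide-type nitrogen, benzyl in place of cyclohexyl provides the first measured step at this position, a 1.1-fold higher number from compound 3 to compound 4 (0.04 log units; within the scatter), so in this assay the two groups cannot be told apart. At the same place, hydrogen in place of phenyl on a saturated chain carbon bound to an amide-type nitrogen and an aromatic carbon gives an at least 1.4-fold lower number from compound 2 to compound 4 (0.15 log units; that floor lies within the scatter), which does not establish a real difference. Compound 2 gives a limit of the assay and not a number, and the step is only a floor because of that limit: the limit of > 100000 nM in this assay, at which 2 of the 4 values shown sit.

Going by these compounds, what remains open is whether any group at this nitrogen can give a clear move in either direction. On these data alone, how a longer chain carrying the phenyl ring, or an amine or a carboxylic acid in place of benzyl, would read in this assay stays unknown.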